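The compounds below may be only part of what the source reports. "The series", "measured", "known", "first", "only" and "open" are said of these compounds alone.

Measured compounds in an ADME assay on Huh7.5.1 cells (Homo sapiens) for cytotoxicity, read by ATP content, with a stated time of 48 h; a lower number here means that less compound is tolerated, a higher number that more compound is tolerated:
compound 1 `Cc1oc(-c2ccc(Cl)c(Cl)c2)nc1CN1CCC(C(=O)NCCCN2C[C@H](C)C[C@H](C)C2)CC1` gives 3170 nM
compound 2 `Cc1ccccc1-c1nc(CN2CCC(C(=O)NCCCN3CCCC(CC(C)C)C3)CC2)c(C)o1` gives 4640 nM
compound 3 `Cc1cccc(Cl)c1-c1nc(CN2CCC(C(=O)NCCCN3CCC(C(C)C)CC3)CC2)c(C)o1` gives 4910 nM

Compound 1 holds the lowest of the three numbers, but its gaps to compound 2 and to compound 3 both lie within the usual scatter, so the three cannot be ranked against one another in this assay. Compound 4 `COc1cccc(OC)c1-c1nc(CN2CCC(C(=O)NCCCN3C[C@H](C)C[C@H](C)C3)CC2)c(C)o1` has not yet been tested. It differs from compound 1 in one place: 2,6-dimethoxyphenyl in place of 3,4-dichlorophenyl on an aromatic carbon. Going by the values given here, no measured pair shows this kind of change, so nothing is known here about how this replacement affects the number. Given that all three measured values sit close together, compound 4 is expected to stay near them, with a step of a 1.3-fold higher number from compound 1 to compound 4 (0.12 log units; within the scatter) that is expected to remain within the scatter. Compound 4 is therefore estimated at 4200 nM, between 1800 nM and 10000 nM.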

Compound 4, half-maximal cytotoxic concentration: 77100 nM
For compound 4 the middle estimate is 18-fold (1.26 log units) below the measured one; the whole stated range lies below it.
By their numbers in this assay, from the lowest: compounds 1, 2 and 3 (each within the scatter of the next); then compound 4.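

In this assay, the group on this aromatic carbon of the five-membered ring proves able to move the number strongly: 2,6-dimethoxyphenyl in place of 3,4-dichlorophenyl brings a 24-fold higher number from compound 1 to compound 4 (1.39 log units; beyond the scatter). Going by these compounds alone, this is the first step between compounds differing in one place, and it shows that this change alone, with the rest of compound 1 kept, is enough to go beyond the scatter. Nothing available here accounts for the step.

The change alters both the substituents and their places on the phenyl ring, so their shares stay unseparated. Going by these compounds, whether 2,6-dichlorophenyl or 3,4-dimethoxyphenyl would follow compound 1 or compound 4 remains open.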